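Nitro for Methoxy on a Weak Dopamine Beta-Hydroxylase Inhibitor

The source may report more compounds than this note shows. Statements on the series, on what has been measured and on what is new or still open speak of the compounds shown alone.

Three compounds sharing one core have numbers in an assay on isolated protein for inhibition of Dopamine beta-hydroxylase (Rattus norvegicus); a lower number here means a stronger inhibitor, a higher number a weaker inhibitor. Compound 1 `S=c1[nH]ccn1Cc1c(Cl)cccc1Cl` gives 708000 nM, compound 2 `COc1ccc(Cn2cc[nH]c2=S)cc1OC` gives 339000 nM, and compound 3 `S=c1[nH]ccn1Cc1ccc(Br)cc1` gives 115000 nM. On these numbers compound 2 stands second highest of the three: its nearest neighbour is compound 1, whose number is higher by a gap beyond the scatter, and its furthest is compound 3, whose number is lower by a gap that also lies beyond the scatter.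

Compound 4 `COc1ccc(Cn2cc[nH]c2=S)cc1[N+](=O)[O-]` has not yet been measured in this assay. It differs from compound 2 in one place: nitro in place of methoxy on an aromatic carbon. Within the data shown here, no pair among the measured compounds shows this change, so no computed step guides the expectation, and the three values give no clear direction for a swap of this kind on that ring.

The account therefore expects compound 4 to stay close to compound 2, with a step from compound 2 to compound 4 of about a 1.4-fold lower number from compound 2 to compound 4 (0.13 log units; within the scatter), a change not clearly beyond the scatter. In this assay compound 4 is estimated at 250000 nM, with a range from 80000 nM to 800000 nM.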

Compound 4, half-maximal inhibitory concentration: 355000 nM
For compound 4 the middle estimate is 1.4-fold (0.15 log units) below the measured one; the range from low to high includes it.
By their numbers in this assay, from the lowest: compound 3; then compounds 2, 4 and 1 (each within the scatter of the next, the first and the last beyond it).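

In this assay, nitro in place of methoxy on an aromatic carbon, ortho to a methoxy group and meta to a group of 7 heavy atoms, gives a 1.0-fold higher number from compound 2 to compound 4 (0.02 log units; within the scatter) and so leaves compounds 2 and 4 indistinguishable, although the entering group has 3 heavy atoms and 2 hydrogen-bond acceptors where the leaving one has 2 heavy atoms and 1 hydrogen-bond acceptor. Among these compounds, the earlier compounds offered no pair differing in one place, so this is the only direct reading of a single position on this ring, and at this weak level of inhibition the swap has no effect that can be told from the scatter. Nothing in the data on hand explains why the two groups read alike.

From the compounds shown here alone, whether this holds for other groups remains open, since an amine, a carboxylic acid or a longer chain on the same aromatic carbon could give a different number. Going by these compounds, it is also open whether nitro would read the same in place of the remaining methoxy group, or in a compound that lacks that methoxy group.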